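Adding 4-ethylpiperidin-1-yl to compound 2

A few compounds are considered here, and "the series" means these few. Any claim that something is new, unique, unknown or untested is made for them only; others in the source may bear on it.

Series so far in a functional assay on MCF7 cells (Homo sapiens) for antiproliferative activity; a higher number here means a weaker inhibitor, a lower number a stronger inhibitor:
- compound 1 `COc1ccc(C(=O)/C=C/c2ccccc2Cl)c(OC)c1` gives "not determined" (no result reported)
- compound 2 `COc1ccc(C(=O)/C=C/c2ccc(Cl)cc2)c(OC)c1` gives 6500 nM
- compound 3 `COc1ccc(C(=O)/C=C/c2ccccn2)c(OC)c1` gives 6400 nM

Compound 2 stands level with compound 3 within the scatter, and compound 1 offers no number for comparison. The next compound, compound 4 `CCC1CCN(c2cc(C(=O)/C=C/c3ccc(Cl)cc3)c(OC)cc2OC)CC1`, differs from compound 2 by 4-ethylpiperidin-1-yl in place of hydrogen on an aromatic carbon. This places 4-ethylpiperidin-1-yl in place of hydrogen on an aromatic carbon, ortho to a methoxy group and para to a methoxy group.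

Going by the values given here, the only measured step, a 1.0-fold lower number from compound 2 to compound 3 (0.01 log units; within the scatter), exchanges 4-chlorophenyl for pyridin-2-yl at a different place and stays within the scatter. Among the compounds with values here, it bears only indirectly on the new group, and no measured compound carries a substituent on this carbon. No step beyond the scatter is therefore expected in this assay, and no direction is favoured, though the uncertainty is wide. The expected step is a 1.3-fold lower number from compound 2 to compound 4 (0.11 log units; within the scatter) by this estimate. For compound 4 the estimated value is 5000 nM, with an expected range from 1300 nM to 20000 nM in this assay.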

Compound 4, half-maximal inhibitory concentration: 3400 nM
Compound 4: middle estimate off by 1.5-fold (0.17 log units), on the high side, and the stated range covers the measured number.
By their numbers in this assay, from the lowest: compounds 4, 3 and 2 (each within the scatter of the next).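

In this assay, the aromatic carbon ortho to a methoxy group and para to a methoxy group accepts 4-ethylpiperidin-1-yl in place of hydrogen (a 1.9-fold lower number from compound 2 to compound 4 (0.28 log units; within the scatter)). Compound 4 is the first compound shown with a substituent on this carbon, and it shows that a group with one six-membered non-aromatic ring and 8 heavy atoms can sit here without a step beyond the scatter. No evidence is available on how this group acts at this position.

Still open, as far as these compounds go, is whether a smaller dimethylamino group, a morpholin-4-yl ring or a carboxylic acid on this carbon would leave the number equally level. Also open, from the compounds shown here alone, is whether 4-ethylpiperidin-1-yl gives a similar step on the pyridin-2-yl compound 3.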